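Replacing the Sulfonyl Aryl Group: Expected Clearance of Compound 4

The source may report more compounds than this note shows. Statements on the series, on what has been measured and on what is new or still open speak of the compounds shown alone.

Compound 1 `COc1cccc(-c2c(S(=O)(=O)c3ccc(OC)c(Cl)c3)cnc3cc(F)ccc23)c1` gives 1.71 mL/min in an ADME assay on microsomes from liver (Homo sapiens) for metabolic stability, tested at 2.5 uM; on this read-out higher numbers stand for fast clearance and lower numbers for slow clearance.
Compound 2 `COc1ccc(S(=O)(=O)c2cnc3cc(F)ccc3c2-c2ccc(F)cc2)cc1Cl` gives 1.29 mL/min in this assay.
Compound 3 `COc1ccc(S(=O)(=O)c2cnc3cc(F)ccc3c2-c2cccc(Cl)c2)cc1Cl` gives 1.19 mL/min in this assay.

Among these three numbers, compound 2 stands second highest. Its nearest neighbour is reached by a 1.1-fold lower number from compound 2 to compound 3 (0.04 log units; within the scatter), and the widest gap to it is a 1.3-fold lower number from compound 1 to compound 2 (0.12 log units; within the scatter); both are within the scatter, so the three compounds cannot be told apart on this read-out.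

Compound 4 `O=S(=O)(c1cccc(F)c1)c1cnc2cc(F)ccc2c1-c1ccc(F)cc1` differs from compound 2 in one place: 3-fluorophenyl in place of 3-chloro-4-methoxyphenyl on a sulfonyl sulfur. For the measured compounds named here, no measured step alters the group on the sulfonyl sulfur, so none matches this change directly. The closest comparisons are the step of a 1.4-fold lower number from compound 1 to compound 3 (0.16 log units; within the scatter), where a chloro stands in for a methoxy on an aromatic carbon, and the step of a 1.3-fold lower number from compound 1 to compound 2 (0.12 log units; within the scatter), where a fluorophenyl replaces a methoxyphenyl; both stayed within the scatter. On that basis no step beyond the scatter is expected for compound 4 in this assay.

Compound 4 is therefore estimated at 1.2 mL/min, with a range from 0.6 mL/min to 2.4 mL/min. This estimate corresponds to an expected step of a 1.1-fold lower number from compound 2 to compound 4 (0.03 log units; within the scatter).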

Compound 4, intrinsic clearance in a liver preparation (reported as CLH), per the amount of preparation that the assay uses: 0.11 mL/min
For compound 4 the middle estimate is 11-fold (1.04 log units) above the measured one; measured number outside the range, below it.
By their numbers in this assay, from the lowest: compound 4; then compounds 3, 2 and 1 (each within the scatter of the next).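

Replacing the group on the sulfonyl sulfur gives, in this assay, a 12-fold lower number from compound 2 to compound 4 (1.07 log units; beyond the scatter), whereas the steps among compounds 1, 2 and 3, none of which alters that group, all stayed within the scatter. Among these four compounds, then, the sulfonyl sulfur is the only place where a change has moved this read-out beyond the scatter, and compound 4 stands clearly apart from the other three, with the lowest number. Nothing measured here bears on why the number falls so far at this position.

On these data alone, this single swap removes the chloro and the methoxy together, exchanges them for a fluoro and leaves the ring in place, so it remains open which of these differences carries the step, and compounds with only one of them altered would be needed to separate them. As far as these compounds go, it is also open whether the low number would hold with a plain phenyl, a pyridine ring or a small chain such as methyl on the sulfonyl sulfur, or with a group other than 4-fluorophenyl elsewhere on the shared core.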